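Cytotoxicity notes: compound 4 against its measured neighbours

This account rests on a few compounds, and the source may have more. Where it says the series, first, only, none or still open, it means among the compounds named here.

compound 1 `CCN(c1ccc(Cl)cc1C)S(=O)(=O)c1cc(Cl)ccc1Cl`: > 5000 nM (a limit)
compound 2 `Cc1cc(Cl)ccc1N(C(F)F)S(=O)(=O)c1cc(Cl)ccc1Cl`: > 5000 nM (a limit)
compound 3 `CCN(c1ccc(Cl)cc1F)S(=O)(=O)c1cc(Cl)ccc1Cl`: > 5000 nM (a limit)

In an ADME assay on A549 cells (Homo sapiens) for cytotoxicity, read by MTT assay (a higher number here means that more compound is tolerated, a lower number that less compound is tolerated), compound 1 gives > 5000 nM, which is a limit of the assay and not a number. The same holds across the set, since (the limit of > 5000 nM in this assay, at which 3 of the 3 values shown sit).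

Compound 4 `CCN(c1c(C)cc(Cl)cc1Cl)S(=O)(=O)c1cc(Cl)ccc1Cl` differs from compound 1 by chloro in place of hydrogen on an aromatic carbon. Within the data shown here, no measured step makes this exact change; the two that start from compound 1 are a step that the two limits leave unreadable from compound 1 to compound 2 and a step that the two limits leave unreadable from compound 1 to compound 3, and both end at the limit, so their size is not readable. Among the measured compounds shown here, the only guide is that every change tried so far has left the limit untouched.

Compound 4 is therefore expected to sit at the limit as well, with an estimated 8000 nM (range 3000 nM to 25000 nM), an expected step that the limit leaves unreadable from compound 1 to compound 4 that is itself unreadable if the assay again reports only a limit.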

Compound 4, half-maximal cytotoxic concentration: > 5000 nM
Compound 4: no number, only a limit; the forecaster's own chance of this, stated with the estimate: 85%; the middle value is on the limit's open side.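

Compound 4, like compound 1, gives only a limit and not a number, so no step between them can be read: the limit of > 5000 nM in this assay, at which 4 of the 4 values shown sit.

The compounds shown leave open whether any change to the shared core gives a measured number rather than a limit.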